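The source may hold more compounds than are shown below. What is called first, only, known or untested is meant among the compounds shown, and "the series" means these compounds.

Measured so far in a functional assay on MCF7 cells (Homo sapiens) for antiproliferative activity, read by MTT assay, with a stated time of 48 h; on this read-out lower numbers stand for stronger inhibition and higher numbers for weaker inhibition
- compound 1 `N=C(N)N/N=C(/C=C/c1ccccc1)c1ccc(Cl)cc1` gives 350 nM
- compound 2 `N=C(N)N/N=C(/C=C/c1ccccc1)c1ccc(Br)cc1` gives 90 nM
- compound 3 `COc1ccc(C(/C=C/c2ccccc2)=N\NC(=N)N)cc1` gives 13000 nM

Compound 1 holds the middle place among these three numbers, with compound 2 lower and compound 3 higher. The next compound, compound 4 `N=C(N)N/N=C(/C=C/c1ccccc1)c1ccc(Cl)c(Cl)c1`, keeps the core of compound 1 and gains one group (chloro in place of hydrogen on an aromatic carbon). This is chloro in place of hydrogen on an aromatic carbon, ortho to a chloro group and meta to a large group.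

Among the compounds with values here, no measured step adds a group to a carbon that carried hydrogen, so the evidence is indirect. All three measured steps exchange one group for another. Bromo for chloro gave a 3.9-fold lower number from compound 1 to compound 2 (0.59 log units; beyond the scatter) and methoxy for chloro gave a 37-fold higher number from compound 1 to compound 3 (1.57 log units; beyond the scatter) in the other direction. Methoxy for bromo gave a 140-fold higher number from compound 2 to compound 3 (2.16 log units; beyond the scatter) as the widest gap.

The entering group in compound 4 is a halogen, so the closer guide is the modest step to compound 2 (a 3.9-fold lower number from compound 1 to compound 2 (0.59 log units; beyond the scatter)), not the large steps to compound 3. A modest step towards a lower number is therefore expected in this assay, though the data do not settle its direction. This estimate means a 2.3-fold lower number from compound 1 to compound 4 (0.37 log units; beyond the scatter) as the expected step. The estimate for compound 4 in this assay is 150 nM with 40 nM to 600 nM as the expected range.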

Compound 4, half-maximal inhibitory concentration: 1900 nM
The estimate for compound 4 lay 13-fold (1.10 log units) below the measured number; the whole stated range lies below it.
By their numbers in this assay, from the lowest: compound 2; then compound 1; then compound 4; then compound 3.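

In this assay, chloro in place of hydrogen on an aromatic carbon, ortho to a chloro group and meta to a large group, gave a 5.4-fold higher number from compound 1 to compound 4 (0.73 log units; beyond the scatter), the first sign that filling this position weakens inhibition. The earlier steps shown here had only exchanged one group for another, and the exchange of bromo for chloro gave a 3.9-fold lower number from compound 1 to compound 2 (0.59 log units; beyond the scatter), so the new step shows that a halogen entering the ring does not by itself bring a lower number: here the number moved the opposite way. The data shown offer no measured reason for this rise.

The compounds shown leave open whether this weaker inhibition belongs to chloro itself or would follow any group placed on this carbon, a question that a fluoro, a methyl or an amine at the same place would help to answer. They also leave open whether the same added chloro would shift the number in the same direction and to a similar extent on compound 2, which carries bromo in place of the first chloro.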